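Adding a Methyl to the Benzyl Ether of Compound 2

The source may hold more compounds than are shown below. What is called first, only, known or untested is meant among the compounds shown, and "the series" means these compounds.

Of the compounds shown here, two have been measured in a functional assay on MNK45 cells (Homo sapiens) for inhibition, read by MTT assay, with a stated time of 48 h; on this read-out lower numbers stand for stronger inhibition and higher numbers for weaker inhibition. Compound 1 `Cc1ccc(COc2ccc(C(=O)NC(=S)Nc3ccc(C)c(-c4nc5ccccc5[nH]4)c3)cc2)cc1` gives 11300 nM. Compound 2 `Cc1ccc(NC(=O)NC(=O)c2ccc(OCc3ccccc3)cc2)cc1-c1nc2ccccc2[nH]1` gives 35100 nM, the higher of the two numbers, and its gap to compound 1 lies beyond the scatter. Compound 3 `Cc1ccc(COc2ccc(C(=O)NC(=O)Nc3ccc(C)c(-c4nc5ccccc5[nH]4)c3)cc2)cc1` awaits measurement; it differs from compound 2 by methyl in place of hydrogen on an aromatic carbon. Among the compounds with values here, no pair of measured compounds isolates this change. The step of a 1.4-fold lower number from compound 2 to compound 3 (0.15 log units; within the scatter) is expected to be small, a modest move toward a lower number that may not exceed the scatter. For compound 3 the estimate is 25000 nM, ranging from 8000 nM to 70000 nM.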

Compound 3, half-maximal inhibitory concentration: 6360 nM
Beside the measured number, compound 3's estimate is 3.9-fold (0.59 log units) above it; the measured number lies below the stated range.
By their numbers in this assay, from the lowest: compounds 3 and 1 (each within the scatter of the next); then compound 2.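

In this assay, the change from benzyl to 4-methylbenzyl gives a 5.5-fold lower number from compound 2 to compound 3 (0.74 log units; beyond the scatter), the only step shown that isolates one change. It shows that this position, para to a large group, is sensitive: a single added methyl carbon moves the number beyond the scatter. Nothing available explains this step.

As far as these compounds go, whether an ethyl group, a methoxy group or an amine at this position would move the number further than methyl remains open. So does whether methyl elsewhere on this ring would have any comparable effect.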